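The source may hold more compounds than are shown below. What is called first, only, known or untested is meant among the compounds shown, and "the series" means these compounds.

Compound 1 `CCCCCc1cc2nn(-c3ccccc3)cc2cn1` carries a pentyl group on the shared core, and in a functional assay on K562 cells (Homo sapiens) for inhibition, read by fluorescence, with a stated time of 72 h (on this read-out higher numbers stand for weaker inhibition of growth and lower numbers for stronger inhibition of growth), compound 1 gives 2100 nM. Compound 2 `CCCCCc1cc2nn(-c3ccccc3)cc2c(C)n1` differs from it by methyl in place of hydrogen on an aromatic carbon and in this assay compound 2 gives 6900 nM, a change of a 3.3-fold higher number from compound 1 to compound 2 (0.52 log units; beyond the scatter). Compound 3 `c1ccc(-n2cc3cnccc3n2)cc1` differs from compound 1 by hydrogen in place of pentyl on an aromatic carbon. In this assay compound 3 reaches only > 100000 nM, which is a limit of the assay and not a number. The change an at least 47-fold higher number from compound 1 to compound 3 (1.67 log units; beyond the scatter) is therefore given only as a floor, since compound 3 sits at the limit of > 100000 nM in this assay, at which 1 of the 3 values shown sits.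

Compound 4 `Cc1nccc2nn(-c3ccccc3)cc12` differs from compound 3 by methyl in place of hydrogen on an aromatic carbon, the same kind of change as from compound 1 to compound 2, though in compound 1 that place is also meta to a pentyl group (5 heavy atoms), whereas in compound 3 it is not. Set beside a 3.3-fold higher number from compound 1 to compound 2 (0.52 log units; beyond the scatter), the expected step that the limit leaves unreadable from compound 3 to compound 4 is small and in the same direction. Compound 4 is therefore expected to stay beyond the limit, at an estimated 250000 nM.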

Compound 4, concentration for 50% growth inhibition: > 100000 nM
Compound 4 gave a limit, no number (the forecaster's own chance of this, stated with the estimate: 85%); the middle value lies beyond the limit too.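

With hydrogen in place of pentyl on the methyl-bearing core, this assay gives an at least 14-fold higher number from compound 2 to compound 4 (1.16 log units; beyond the scatter). The same change points the same way on the core without the methyl, so its direction carries across these two cores, while its size cannot be compared: the same change on two cores in this assay, an at least 47-fold higher number (1.67 log units; beyond the scatter) from compound 1 to compound 3 and an at least 14-fold higher number (1.16 log units; beyond the scatter) from compound 2 to compound 4; the limit leaves it open whether they differ Methyl in place of hydrogen cannot be read on the core without pentyl, so these compounds do not show whether that step carries over, and compound 3 and compound 4 both stand at a limit: the limit of > 100000 nM in this assay, at which 2 of the 4 values shown sit.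

From the compounds shown here alone, it remains open how much of the chain is needed, as only pentyl and hydrogen appear at that place. A shorter chain, a longer chain or an amine there could each give a different result.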